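The compounds below may be only part of what the source reports. "The series", "measured", "known", "first", "only" and "open" are said of these compounds alone.

Measured in a functional assay on KG-1 cells (Homo sapiens) for cytotoxicity, read by luminescence and CellTiter-Glo, with a stated time of 3 days; a lower number here means a stronger inhibitor, a higher number a weaker inhibitor:
- compound 1 `O=C(Nc1cc(C(F)(F)F)cc(C(F)(F)F)c1)c1cc(Cl)c(F)cc1O`: 470 nM
- compound 2 `O=C(Nc1cc(C(F)(F)F)cc(C(F)(F)F)c1)c1cc(Br)c(-c2ccccc2)cc1O`: 300 nM
- compound 3 `O=C(Nc1cc(C(F)(F)F)cc(C(F)(F)F)c1)c1ccc(-c2ccccc2)cc1O`: 860 nM

In this assay compound 3, at 860 nM, lies within the scatter of compound 1 but stands clearly above compound 2. The next compound, compound 4 `O=C(Nc1cc(C(F)(F)F)cc(C(F)(F)F)c1)c1cc(Cl)c(-c2ccccc2)cc1O`, is compound 3 with one change: chloro in place of hydrogen on an aromatic carbon. The new chloro sits ortho to a phenyl group and para to a hydroxy group.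

For the measured compounds named here, one measured step bears on this change: a 2.9-fold higher number from compound 2 to compound 3 (0.46 log units; beyond the scatter). That step is hydrogen in place of bromo at the same carbon, so it is the reverse of a halogen being added, and it is modest. Read backwards, it points to a lower number on adding chloro. The halogen differs, however, and the evidence is a single pair, so the size of the step carries over only loosely.

A step of similar or slightly smaller size is expected. The expected change is a 2.3-fold lower number from compound 3 to compound 4 (0.35 log units; beyond the scatter). Compound 4 is estimated at 380 nM, with an expected range of 180 nM to 750 nM.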

Compound 4, half-maximal inhibitory concentration: 430 nM
The estimate for compound 4 lay 1.1-fold (0.05 log units) below the measured number, and the stated range covers the measured number.
By their numbers in this assay, from the lowest: compounds 2, 4, 1 and 3 (each within the scatter of the next, the first and the last beyond it).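

In this assay the step for chloro in place of hydrogen is a 2.0-fold lower number from compound 3 to compound 4 (0.30 log units; within the scatter) and so does not clear the scatter, whereas the step for hydrogen in place of bromo at this same carbon did. Chloro in place of bromo gives a 1.4-fold higher number from compound 2 to compound 4 (0.16 log units; within the scatter) and leaves the two halogens unresolved at this carbon, while phenyl in place of fluoro at the second varied site, with chloro held, gives a 1.1-fold lower number from compound 1 to compound 4 (0.04 log units; within the scatter) and leaves those two groups unresolved as well. No measurement at hand accounts for any of these steps.

Still open, going by these compounds, is whether a non-halogen group at the chloro carbon, such as an amine or a nitrile, would separate from hydrogen beyond the scatter. Also open, on these data alone, is how a carboxylic acid or a longer chain would compare with phenyl at the second site.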